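Swapping nitro for iodo on the aryl urea of compound 1

This account rests on a few compounds, and the source may have more. Where it says the series, first, only, none or still open, it means among the compounds named here.

Compound 1 `CCc1nc2ccccc2c(=O)n1NC(=O)Nc1ccc([N+](=O)[O-])cc1` shows the lowest number of the three measured compounds in a functional assay on the whole organism (strain albino) with Mus musculus as the target, at a dose of 100 mg/kg by the intraperitoneal route; a lower number here means less inhibition, a higher number more inhibition at the dose given (going by the name of the read-out): compound 1 gives 41%, while compound 2 `O=C(Nc1ccc(Cl)cc1)Nn1c(-c2ccccc2)nc2ccccc2c1=O` gives 55% and compound 3 `Cc1cccc(NC(=O)Nn2c(-c3ccccc3)nc3ccccc3c2=O)c1` gives 59%, both gaps lying beyond the scatter. Compound 4 `CCc1nc2ccccc2c(=O)n1NC(=O)Nc1ccc(I)cc1` differs from compound 1 by iodo in place of nitro on an aromatic carbon. Among the measured compounds shown here, the only measured step that touches this aryl ring is a number 4 percentage points higher from compound 2 to compound 3 (within the scatter), a change on a different core that stayed within the scatter. On that basis no step beyond the scatter is expected for this assay, and compound 4 is estimated at 45%, from 30% to 60%, which means an expected step of a number 4 percentage points higher from compound 1 to compound 4 (within the scatter).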

Compound 4, a percentage reported as inhibition, in the whole organism at one dose (the size of the read-out at that dose, not a potency): 55%
Beside the measured number, compound 4's estimate is 10 percentage points below it; the measured number falls inside the stated range.
By their numbers in this assay, from the lowest: compound 1; then compounds 2, 4 and 3 (each within the scatter of the next).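

On the core of compound 1, the aromatic carbon para to a large group responds to its substituent: in this assay, iodo in place of nitro gives a number 14 percentage points higher from compound 1 to compound 4 (beyond the scatter) on this ring. Among the compounds shown here, the earlier step on an aryl ring, a number 4 percentage points higher from compound 2 to compound 3 (within the scatter), did not show this, so this swap is the first single change to pass the scatter. Nothing shown explains why the number moves with this swap.

The compounds shown leave open whether an amine or a methoxy group on this same carbon would behave like iodo or like nitro. They also leave open whether the swap carries over to the core of compound 2.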